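Replacing the dimethoxyphenyl on the ring nitrogen

The source may report more compounds than this note shows. Statements on the series, on what has been measured and on what is new or still open speak of the compounds shown alone.

Compound 1 `COc1ccc(OC)c(N2C(=O)CSC2c2cccc(C(=O)NCCCCc3ccccc3)c2)c1` is the reference point of this step. In a functional assay on MG-63 cells (Homo sapiens) for inhibition, read by CCK-8 assay, with a stated time of 72 h, tested at 1 uM (on this read-out lower numbers stand for less inhibition and higher numbers for more inhibition at the one concentration tested (going by the name of the read-out)), compound 1 gives 92%, the highest of the two numbers in hand. Going by the values given here, compound 2 `COc1ccccc1N1C(=O)CSC1C(=O)NCCCCc1ccccc1` is the only other measured member of the set; in this assay compound 2 gives 60%, which lies below compound 1 by more than the usual scatter, though the two structures differ in several places and no single-change step connects them.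

Compound 3 `O=C(NCCCCc1ccccc1)c1cccc(C2SCC(=O)N2c2ccccc2)c1` has not yet been measured. It differs from compound 1 in one place: phenyl in place of 2,5-dimethoxyphenyl on an amide-type nitrogen in a ring. The rest of the shared core, including the amide chain, is kept unchanged.

Among the compounds with values here, no measured pair differs only in this way, so the size of the step rests on judgment alone. A decrease in this assay beyond the scatter is expected, of moderate size rather than a collapse. The expected change is the step of a number 22 percentage points lower from compound 1 to compound 3 (beyond the scatter). Compound 3 is accordingly estimated to give 70% in this assay, with a range from 45% to 90%.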

Compound 3, a percentage reported as inhibition, at one concentration (the size of the read-out at that concentration, not a potency): 89%
Estimate against measurement, compound 3: 19 percentage points below, within the range that was stated.
By their numbers in this assay, from the lowest: compound 2; then compounds 3 and 1 (each within the scatter of the next).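

In this assay, replacing 2,5-dimethoxyphenyl with phenyl on the amide-type nitrogen in a ring gives a number 3 percentage points lower from compound 1 to compound 3 (within the scatter), so this pair cannot be told apart at the one concentration tested. In this pair, then, the two methoxy groups are not required for a high percentage of inhibition, and the plain phenyl ring serves as well as the larger 2,5-dimethoxyphenyl on this read-out. The data on hand offer no explanation for this result.

The compounds shown leave open whether an aromatic ring is needed at this position at all, and how a methyl group, a longer alkyl chain, or a phenyl ring carrying an amine or a carboxylic acid would read in this assay. They also leave open whether compound 1 and compound 3 would still match across a series of concentrations, as a percentage at a single concentration is not a potency and could hide a difference between them.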